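Sulfonamide pair on two benzamide cores

A few compounds are considered here, and "the series" means these few. Any claim that something is new, unique, unknown or untested is made for them only; others in the source may bear on it.

Measured compounds:
compound 1 `COc1ccccc1C(=O)NCc1ccc(CNS(=O)(=O)c2ccccc2F)cc1`, 1 nM
compound 2 `COc1ccccc1C(=O)NCc1ccc(CNS(=O)(=O)c2ccc([N+](=O)[O-])cc2)cc1`, 100 nM
compound 3 `Cc1ccccc1C(=O)NCc1ccc(CNS(=O)(=O)c2ccccc2F)cc1`, 1000 nM

Of the compounds shown here, three have been measured in an assay on MDA-MB-231 cells for displacement of a labelled ligand from C-X-C chemokine receptor type 4 (Homo sapiens), read by fluorescence and microscopy, with stated times of 10 min and 30 min (on this read-out lower numbers stand for an effect already at smaller amounts and higher numbers for an effect only at larger amounts of compound), and a fourth, compound 4 `Cc1ccccc1C(=O)NCc1ccc(CNS(=O)(=O)c2ccc([N+](=O)[O-])cc2)cc1`, has not. Compound 1 gives the lowest number of the three. Compound 2 is separated from it by 4-nitrophenyl in place of 2-fluorophenyl on a sulfonyl sulfur, and this brings a 100-fold higher number from compound 1 to compound 2 (2.00 log units; beyond the scatter). Compound 3 differs from compound 1 by methyl in place of methoxy on an aromatic carbon, and this brings a 1000-fold higher number from compound 1 to compound 3 (3.00 log units; beyond the scatter). Compound 3 stands highest of the three, with compound 2 nearest and compound 1 furthest. Among the compounds with values here, no step is computed between compound 2 and compound 3; their values simply show compound 3 higher than compound 2.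

Compound 4 is related to compound 3 by 4-nitrophenyl in place of 2-fluorophenyl on a sulfonyl sulfur. This is the same change as the one that separates compound 1 from compound 2, made on a different core: the core of compound 3 carries the methyl where the core of compound 1 carries the methoxy, as described above. The place of the change reads the same in both cases.

For compound 4 a large step in the same direction is expected, a 30-fold higher number from compound 3 to compound 4 (1.48 log units; beyond the scatter), set beside the earlier one; this rests on the change having given a 100-fold higher number from compound 1 to compound 2 (2.00 log units; beyond the scatter), while the starting point is already the high value of compound 3, 1000 nM, so that a somewhat smaller step than the earlier one is allowed for. The estimate for compound 4 in this assay is 30000 nM, with a range from 5000 nM to 200000 nM, and a fair chance that only a limit is reported.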

Compound 4, effective concentration (reported as EC, without a stated level of effect): 100 nM
Estimate against measurement, compound 4: 300-fold (2.48 log units) above; the measured number lies below the stated range.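

In this assay, 4-nitrophenyl in place of 2-fluorophenyl on a sulfonyl sulfur brings a 10-fold lower number from compound 3 to compound 4 (1.00 log units; beyond the scatter), so on the methyl core the change runs opposite to its direction on the methoxy core: the same change on two cores in this assay, a 100-fold higher number (2.00 log units; beyond the scatter) from compound 1 to compound 2 and a 10-fold lower number (1.00 log units; beyond the scatter) from compound 3 to compound 4, 1000-fold (3.00 log units) apart, beyond the scatter of two such steps Methyl in place of methoxy on an aromatic carbon shows the same dependence on context, with no change at the digits printed from compound 2 to compound 4 (within the scatter), so its effect in this set depends on the group held by the sulfonyl sulfur: the same change on two cores in this assay, a 1000-fold higher number (3.00 log units; beyond the scatter) from compound 1 to compound 3 and no change at the digits printed (within the scatter) from compound 2 to compound 4, 1000-fold (3.00 log units) apart, beyond the scatter of two such steps The four compounds show that neither change can be carried from one core to another in this series as a fixed step, but they do not show what underlies this or whether it extends beyond this single set of two cores and two sulfonyl substituents.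

The compounds shown leave open how the series behaves when the sulfonyl sulfur carries something other than these two aromatic groups, such as an amine-bearing ring or a longer alkyl chain. They also leave open whether a group such as a chlorine or an ethoxy on the aromatic carbon would follow the methoxy core or the methyl core.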